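This account rests on a few compounds, and the source may have more. Where it says the series, first, only, none or still open, it means among the compounds named here.

Working notes on the S-carbamoyl cysteine series. Compound 1 is `CC(=O)N[C@@H](CSC(=O)Nc1ccccc1F)C(=O)O` and compound 2 is `COc1ccc(NC(=O)SC[C@H](NC(C)=O)C(=O)O)cc1`; both carry the same acetylated cysteine acid, and differ only in the aryl amide. In a functional assay on OVCAR-3 cells (Homo sapiens) for cytotoxicity, read by MTT assay, with a stated time of 6 days (a higher number here means a weaker inhibitor, a lower number a stronger inhibitor), compound 1 gives > 200000 nM, which is a limit of the assay and not a number. In this assay compound 2 likewise gives > 200000 nM, again a limit rather than a measured value. Going by the values given here, compound 2 thus stands nowhere on a numerical scale: only a limit is known for it, and the one other value is a limit too, as the limit of > 200000 nM in this assay, at which 2 of the 2 values shown sit, shows.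

The next compound, compound 3, is `CC(=O)N[C@@H](CSC(=O)Nc1ccc(Br)cc1)C(=O)O`. Relative to compound 2 the change is bromo in place of methoxy on an aromatic carbon.

Among the compounds with values here, no measured step exists between compounds here, so nothing points to a shift in this assay. The expectation is a step that the limit leaves unreadable from compound 2 to compound 3, within the scatter. Compound 3 is therefore estimated at 300000 nM, in the range 150000 nM to 1000000 nM, most probably reported again only as a limit.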

Compound 3, half-maximal inhibitory concentration: > 200000 nM
Compound 3: no number, only a limit; the forecaster's own chance of this, stated with the estimate: 85%; the middle value does not contradict the limit.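

No step from compound 2 to compound 3 can be read, since both compounds sit at a limit and not at a number: the limit of > 200000 nM in this assay, at which 3 of the 3 values shown sit.

The compounds shown leave open how methoxy and bromo would rank on a numerical scale, and whether any aryl amide of the series gives a numerical value.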